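The source may hold more compounds than are shown below. What is called first, only, known or untested is meant among the compounds shown, and "the series" means these compounds.

Measured in an in vitro ADME assay on microsomes (Homo sapiens) for pharmacokinetics; a higher number here means faster removal of the compound, a lower number slower removal:
- compound 1 `CC(C)(C)C1CCNC(=O)C(N(Cc2ccc(C(=O)NC3CC3)cc2)S(=O)(=O)c2ccc(Cl)cc2)C1`: 93 mL.min-1.g-1
- compound 2 `COc1ccc(CN([C@@H]2CC(F)(F)CCNC2=O)S(=O)(=O)c2ccc(Cl)cc2)cn1`: 9 mL.min-1.g-1
- compound 3 `CC(C)C1CCNC(=O)C(N(Cc2ccc(C(=O)NC3CC3)cc2)S(=O)(=O)c2ccc(Cl)cc2)C1`: 51 mL.min-1.g-1

Compound 2 has the lowest number of the three, and the values of compound 3 and compound 1 both stand beyond the scatter above it.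

The next compound is compound 4 `COc1ccc(CN([C@@H]2CC(F)(F)CCNC2=O)S(=O)(=O)c2ccc(Cl)cc2)c(F)c1`. It differs from compound 2 as follows: 2-fluoro-4-methoxyphenyl in place of 6-methoxypyridin-3-yl on a saturated chain carbon bound to a sulfonamide nitrogen. The change is therefore 2-fluoro-4-methoxyphenyl in place of 6-methoxypyridin-3-yl.

Going by the values given here, the only measured step, a 1.8-fold lower number from compound 1 to compound 3 (0.26 log units; within the scatter), lies elsewhere in the structure and within the scatter, so it says nothing about this change. Among the compounds with values here, no measured pair isolates this exchange. The sole, weak hint comes from compound 3 at 51 mL.min-1.g-1 and compound 1 at 93 mL.min-1.g-1, which both carry a carbon-only aromatic ring but also differ from compound 2 in other places.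

A modest upward move is therefore expected in this assay, with low confidence. The expected change is a 2.2-fold higher number from compound 2 to compound 4 (0.35 log units; beyond the scatter). For compound 4 the estimated value is 20 mL.min-1.g-1, with an expected range of 9 mL.min-1.g-1 to 50 mL.min-1.g-1.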

Compound 4, intrinsic clearance in microsomes: 13 mL.min-1.g-1
Beside the measured number, compound 4's estimate is 1.5-fold (0.19 log units) above it; the range from low to high includes it.
By their numbers in this assay, from the lowest: compounds 2 and 4 (each within the scatter of the next); then compounds 3 and 1 (each within the scatter of the next).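

In this assay the exchange of 6-methoxypyridin-3-yl for 2-fluoro-4-methoxyphenyl, on a saturated chain carbon bound to a sulfonamide nitrogen, gives a 1.4-fold higher number from compound 2 to compound 4 (0.16 log units; within the scatter) and so no readable change. Going by these compounds alone, this is the first matched pair at this position, and it shows that a carbon-only aromatic ring carrying fluorine can stand here, on this shared core, without a move beyond the scatter. No supporting data bear on the reason for this result.

On these data alone, the exchange removes the ring nitrogen and adds the fluorine in a single step, so the separate contribution of each stays open. Also open, as far as these compounds go, is how the number responds to a different kind of group in this place, such as a plain benzyl, an aliphatic amine or a carboxylic acid.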